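From fluoro to chloro: what to expect of compound 3

The source may report more compounds than this note shows. Statements on the series, on what has been measured and on what is new or still open speak of the compounds shown alone.

Compound 1 `CCCN1CCN(c2ccc(S(=O)(=O)Oc3ccccc3OC)cc2)C1=O`: > 100000 nM
Compound 2 `CCCN1CCN(c2ccc(S(=O)(=O)Oc3ccc(F)cc3)cc2)C1=O`: 23000 nM

In a functional assay on HT-29 cells (Homo sapiens) for antiproliferative activity, read by sulforhodamine B assay, with a stated time of 48 h (a higher number here means a weaker inhibitor, a lower number a stronger inhibitor), compound 1 gives > 100000 nM, which is a limit and not a number. Among the measured compounds shown here, compound 2 therefore holds the only true number, 23000 nM. Compound 3 `CCCN1CCN(c2ccc(S(=O)(=O)Oc3ccc(Cl)cc3)cc2)C1=O` has chloro in place of fluoro on an aromatic carbon, para to a large group (chloro in place of fluoro on an aromatic carbon). For the measured compounds named here, the one measured step, an at least 4.3-fold lower number from compound 1 to compound 2 (0.63 log units; beyond the scatter), replaced 2-methoxyphenyl with 4-fluorophenyl, so it offers only loose guidance for this smaller swap. Little change is therefore expected in this assay, with at most a slight lean towards a lower number. The expected step is a 1.5-fold lower number from compound 2 to compound 3 (0.19 log units; within the scatter). For compound 3 the estimate is 15000 nM, with an expected range of 5000 nM to 45000 nM.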

Compound 3, half-maximal inhibitory concentration: 15000 nM
The estimate for compound 3 equals the measured number at the digits printed, within the range that was stated.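

Swapping fluoro for chloro on this aromatic carbon gives a 1.5-fold lower number from compound 2 to compound 3 (0.19 log units; within the scatter) in this assay, so the two compounds cannot be told apart here. The chloro compound also shows an at least 6.6-fold lower number from compound 1 to compound 3 (0.82 log units; beyond the scatter), so a second halogen now stands clear of the 2-methoxyphenyl compound. This comparison rests on a limit, not a true number: the limit of > 100000 nM in this assay, at which 1 of the 3 values shown sits.

Still open, as far as these compounds go, is whether a methyl group or an amine at this same place would match the two halogens. Also unsettled is whether the methoxy group itself or its location sets compound 1 apart.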